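The source may report more compounds than this note shows. Statements on the series, on what has been measured and on what is new or still open speak of the compounds shown alone.

Three measured compounds share one core and differ only in the group carried on a carbonyl carbon. Compound 1 `O=C(C1CCC(F)(F)CC1)N1CCc2nc(C#Cc3ccccc3)sc2C1` gives 70 nM in an assay on HEK293 cells for positive allosteric modulation of metabotropic glutamate receptor 5 (Homo sapiens), read by FLIPR, with a stated time of 1 h; on this read-out higher numbers stand for an effect only at larger amounts of compound and lower numbers for an effect already at smaller amounts. Compound 2 `CC1CCC(C(=O)N2CCc3nc(C#Cc4ccccc4)sc3C2)CC1` gives 190 nM in this assay, and compound 3 `O=C(c1cccc(Cl)c1)N1CCc2nc(C#Cc3ccccc3)sc2C1` gives 8.7 nM in this assay, the lowest of the three numbers. The steps among them are a 2.7-fold higher number from compound 1 to compound 2 (0.43 log units; beyond the scatter), an 8.0-fold lower number from compound 1 to compound 3 (0.91 log units; beyond the scatter) and a 22-fold lower number from compound 2 to compound 3 (1.34 log units; beyond the scatter), so exchanging either saturated ring for the aromatic ring lowered the number clearly.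

Compound 4 `Cc1nc(C(=O)N2CCc3nc(C#Cc4ccccc4)sc3C2)cs1` is not yet measured. It differs from compound 3 by 2-methyl-1,3-thiazol-4-yl in place of 3-chlorophenyl on a carbonyl carbon. Within the data shown here, no measured step swaps one aromatic ring for another, so the two steps that end at compound 3 are the only guide, and both concern a saturated ring giving way to an aromatic one rather than the present change. Going by these compounds, because compound 3 sits at 8.7 nM after such an exchange, an aromatic ring on this carbon appears to be favourable, but whether a five-membered ring with two hetero atoms holds that number is untested. For compound 4 the expected step is a 4.0-fold higher number from compound 3 to compound 4 (0.60 log units; beyond the scatter), a modest rise in the number. Compound 4 is therefore estimated at 35 nM in this assay, with a range from 9 nM to 140 nM.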

Compound 4, half-maximal effective concentration: 220 nM
Estimate against measurement, compound 4: 6.3-fold (0.80 log units) below; measured number above the stated range.
By their numbers in this assay, from the lowest: compound 3; then compound 1; then compounds 2 and 4 (each within the scatter of the next).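

An aromatic ring on this carbonyl carbon is not enough on its own to give a low number: in this assay the exchange of 3-chlorophenyl for 2-methyl-1,3-thiazol-4-yl gives a 25-fold higher number from compound 3 to compound 4 (1.40 log units; beyond the scatter), so among the aromatic groups shown, the low number goes with 3-chlorophenyl and not with compound 4. The earlier hint that aromatic rings beat saturated ones also fails here: replacing 4-methylcyclohexyl gives a 1.2-fold higher number from compound 2 to compound 4 (0.06 log units; within the scatter), so the two groups cannot be told apart, while replacing 4,4-difluorocyclohexyl gives a 3.1-fold higher number from compound 1 to compound 4 (0.50 log units; beyond the scatter), which goes the opposite way from the exchange that led to compound 3. Nothing shown here explains why these two aromatic groups differ so widely.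

This single change alters several things at once: the ring size, the hetero atoms, the chlorine and the methyl group, so the compounds shown cannot say which of these matters. Plain phenyl, 3-methylphenyl or a pyridine ring on the same carbonyl carbon would help to separate them, as would a thiazole ring without its methyl group.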